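Methoxy for hydrogen on an aryl ring of compound 3

The source may hold more compounds than are shown below. What is called first, only, known or untested is meant among the compounds shown, and "the series" means these compounds.

Measured compounds and their numbers in a functional assay on U-251 cells (Homo sapiens) for inhibition, read by sulforhodamine B assay, with a stated time of 48 h, tested at 10 uM; a lower number here means less inhibition of growth, a higher number more inhibition of growth at the concentration tested:
compound 1 `COc1cc(-c2nc(N)n(CC(=O)Nc3ccc(/C(C)=N\O)cc3)n2)cc(OC)c1OC` — compound 1 gives 14.2%
compound 2 `C/C(=N/O)c1ccc(NC(=O)Cn2nc(-c3ccccc3)nc2N)cc1` — compound 2 gives 8.76%
compound 3 `c1ccc(-c2nc3sc(-c4ccccc4)cn3n2)cc1` — compound 3 gives 6%

Compound 3 stands lowest of the three numbers in this assay, but both gaps lie within the usual scatter of this read-out: compound 2 is nearest, compound 1 furthest, and neither separation can be taken as a real difference. All three compounds therefore sit in the same weak band, with growth of these cells barely touched at the concentration tested. Within the data shown here, compound 1 and compound 2 share a core of their own and differ from compound 3 in more than one place, so no single step between measured compounds is available.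

The next compound, compound 4 `COc1ccc(-c2nc3sc(-c4ccccc4)cn3n2)cc1`, differs from compound 3 in one place: methoxy in place of hydrogen on an aromatic carbon.

Among the measured compounds shown here, nothing among the measured compounds shows what a change of this kind does here. With compound 3 already near the bottom of the scale, the step of a number 2 percentage points higher from compound 3 to compound 4 (within the scatter) is expected to stay within the scatter, with no direction favoured. Compound 4 is therefore estimated at 8%, with a range from 0% to 18%.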

Compound 4, percent growth inhibition at one concentration: 21%
Compound 4: middle estimate off by 13 percentage points, on the low side, and the stated range ends below it.
By their numbers in this assay, from the lowest: compounds 3, 2, 1 and 4 (each within the scatter of the next, the first and the last beyond it).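

In this assay, among these compounds, the exchange of hydrogen for methoxy on an aromatic carbon of a six-membered aromatic ring of carbon only, para to a large group, gives a number 15 percentage points higher from compound 3 to compound 4 (beyond the scatter) and is the first single change that can be read. This carbon is therefore not a silent position in this core, since one methoxy group is enough to move the number out of the scatter, although compound 4 at 21% still leaves most growth of these cells untouched at the concentration tested. Nothing available on these compounds accounts for the step, so it stands as an observation without an explanation.

One step cannot show whether the gain belongs to methoxy itself or to any group at this carbon, and a hydroxyl, an amine, a chlorine atom or a longer chain such as ethoxy in the same place would separate those readings. Also open, from the compounds shown here alone, is whether methoxy at another carbon of this ring, or a second and third methoxy group on it, would add to the number or take it back into the scatter.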